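The source may report more compounds than this note shows. Statements on the series, on what has been measured and on what is new or still open speak of the compounds shown alone.

Series notes, metabolic stability. Three compounds sharing one core have been run in an ADME assay on microsomes from liver (Rattus norvegicus) for metabolic stability, read by LC-MS, with a stated time of 30 min, tested at 0.1 uM (on this read-out higher numbers stand for a more stable compound and lower numbers for a less stable compound), so far. Compound 1 `COc1cccc(Nc2cc3[nH]c(-c4cccc(C(F)(F)F)c4)nc3cn2)n1` gives 49%. Compound 2 `COc1cccnc1Nc1cc2[nH]c(-c3cccc(C(F)(F)F)c3)nc2cn1` gives 83%. Compound 3 `COc1ccc(Nc2cc3[nH]c(-c4cccc(C(F)(F)F)c4)nc3cn2)nc1` gives 32%. Compound 2 thus stands highest of the three, with the step of a number 34 percentage points higher from compound 1 to compound 2 (beyond the scatter) and the step of a number 51 percentage points lower from compound 2 to compound 3 (beyond the scatter) both beyond the scatter; the remaining step, a number 17 percentage points lower from compound 1 to compound 3 (beyond the scatter), is modest but also beyond the scatter.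

The next compound, compound 4 `FC(F)(F)c1cccc(-c2nc3cnc(Nc4cccnn4)cc3[nH]2)c1`, differs from compound 2 by pyridazin-3-yl in place of 3-methoxypyridin-2-yl on a nitrogen on an aromatic ring. Among the measured compounds shown here, none of the measured steps covers this change directly: each of them only moves the methoxy group from one position of the pyridinyl ring to another, yet those moves already shifted the read-out by large amounts, so the ring on that nitrogen clearly matters here. The change to compound 4 removes the methoxy group altogether and replaces the ring by a pyridazin-3-yl. The measured steps therefore give direction only loosely. A downward step from the high value of compound 2 is expected, of moderate size, with wide uncertainty: for compound 4 the estimate is a number 28 percentage points lower from compound 2 to compound 4 (beyond the scatter), that is 55% in this assay, within 30% to 85%.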

Compound 4, percent of the compound remaining: 69%
For compound 4 the middle estimate is 14 percentage points below the measured one; the range from low to high includes it.
By their numbers in this assay, from the lowest: compound 3; then compound 1; then compound 4; then compound 2.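

In this assay the ring on this nitrogen does not need a methoxy group to give a high number: with pyridazin-3-yl the read-out is a number 20 percentage points higher from compound 1 to compound 4 (beyond the scatter) and a number 37 percentage points higher from compound 3 to compound 4 (beyond the scatter), so this unsubstituted ring ranks above both 6-methoxypyridin-2-yl and 5-methoxypyridin-2-yl. 3-Methoxypyridin-2-yl still keeps the top place, with a number 14 percentage points lower from compound 2 to compound 4 (beyond the scatter), but it no longer stands alone at the upper end, and the position tolerates a change of ring as well as a move of the methoxy group. Nothing at hand bears on the reason for this order.

The step to compound 4 changes the ring and removes the methoxy group in one move, so the contribution of each remains unresolved; unsubstituted pyridin-2-yl and a methoxy-bearing pyridazin-3-yl would separate the two. Also open, as far as these compounds go, is how this position responds to other groups on the ring, such as an amine, a nitrile or a longer alkoxy chain, and whether pyridazin-3-yl would keep its rank with these in place.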